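An Ester Gives Way to a Carboxylic Acid

The source may hold more compounds than are shown below. What is called first, only, known or untested is meant among the compounds shown, and "the series" means these compounds.

Compound 3 `COC(=O)c1ccc(OCCCCOc2ccc(C(=O)CC(C)C)c(O)c2C)cc1` gives 22.7% in an assay on HEK293 cells for positive allosteric modulation of metabotropic glutamate receptor 3 (Rattus norvegicus), read by thallium flux, with a stated time of 2.5 min (on this read-out higher numbers stand for larger maximal responses and lower numbers for smaller maximal responses), the lowest of the three measured numbers. Compound 1 `Cc1c(OCCCCOc2ccccc2C(=O)O)ccc(C(=O)CC(C)C)c1O` gives 28.1%, and the two sit within the scatter of each other, as a number 5.4 percentage points lower from compound 1 to compound 3 (within the scatter) shows. Compound 2 `Cc1c(OCCCCOc2ccc(C(=O)O)cc2F)ccc(C(=O)CC(C)C)c1O` gives 67.7%, and the step of a number 45 percentage points lower from compound 2 to compound 3 (beyond the scatter) is large. Compound 4 `Cc1cc(OCCCCOc2ccc(C(=O)CC(C)C)c(O)c2C)ccc1C(=O)O` differs from compound 3 by 4-carboxy-3-methylphenyl in place of 4-(methoxycarbonyl)phenyl on an oxygen on a saturated carbon. The measured step that bears most on this change is a number 45 percentage points lower from compound 2 to compound 3 (beyond the scatter), which swapped a carboxylic acid for a methyl ester; compound 4 restores an acid, though it carries a methyl where compound 2 carries fluorine. Compound 1, also an acid, gives 28.1%, close to compound 3, so an acid alone does not assure a large response. A rise beyond the scatter is nevertheless expected, and compound 4 is expected to show a number 32.3 percentage points higher from compound 3 to compound 4 (beyond the scatter) in this assay. Compound 4 is estimated at 55%, with a range from 30% to 75%.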

Compound 4, largest response reached (reported as percent of maximum), in percent of the reference or control that the assay uses: 41.9%
The estimate for compound 4 lay 13.1 percentage points above the measured number, within the range that was stated.
By their numbers in this assay, from the lowest: compounds 3 and 1 (each within the scatter of the next); then compound 4; then compound 2.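

At this place, on an oxygen on a saturated carbon, 4-carboxy-3-methylphenyl in place of 4-(methoxycarbonyl)phenyl gives a number 19.2 percentage points higher from compound 3 to compound 4 (beyond the scatter) in this assay, so a second acid now stands clear of the ester, while compound 1, also an acid, stays within the scatter of it. The three acids also separate from one another, with a number 25.8 percentage points lower from compound 2 to compound 4 (beyond the scatter) and a number 13.8 percentage points higher from compound 1 to compound 4 (beyond the scatter), so the response follows the whole substituted ring and not the acid alone. No measurement at hand gives a reason for these gaps.

4-Carboxy-2-fluorophenyl and 4-carboxy-3-methylphenyl differ both in the added group and in its place on the ring, so which of the two changes counts stays open. On these data alone, how 4-carboxy-3-fluorophenyl, 4-carboxy-2-methylphenyl or a tetrazole in place of the carboxylic acid would read also stays open.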